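This account rests on a few compounds, and the source may have more. Where it says the series, first, only, none or still open, it means among the compounds named here.

Compound 3 `CC(C)(Oc1ccccc1)C1OCC(C/C=C\CCC(=O)O)C(c2cccnc2)O1` stands second highest of the three numbers in an assay for inhibition of Thromboxane-A synthase (Homo sapiens), using microsomes; on this read-out higher numbers stand for weaker inhibition and lower numbers for stronger inhibition: in this assay compound 3 gives 52 nM. Its nearest neighbour is compound 1 `O=C(O)CC/C=C\CC1COC(c2ccc(C(F)(F)F)cc2)OC1c1cccnc1`, which in this assay gives 44 nM, so that a 1.2-fold higher number from compound 1 to compound 3 (0.07 log units; within the scatter) lies within the scatter. Its furthest neighbour is compound 2 `O=C(O)CC/C=C\CC1COC(c2ccsc2)OC1c1cccnc1`, which in this assay gives 500 nM; the step of a 9.6-fold lower number from compound 2 to compound 3 (0.98 log units; beyond the scatter) is beyond the scatter, as is an 11-fold higher number from compound 1 to compound 2 (1.06 log units; beyond the scatter).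

Compound 4 `COc1ccccc1OC(C)(C)C1OCC(C/C=C\CCC(=O)O)C(c2cccnc2)O1` is obtained from compound 3 through (methoxy in place of hydrogen on an aromatic carbon), the change placed on an aromatic carbon of the six-membered aromatic ring of carbon only, ortho to a large group; read one bond further out, phenoxy becomes 2-methoxyphenoxy.

Within the data shown here, none of the measured steps touches a substituent on this aryl ring: each of them exchanges the whole group on the saturated ring carbon. The nearest guide is a 1.2-fold higher number from compound 1 to compound 3 (0.07 log units; within the scatter), where a wholesale exchange of one aryl group for another left the number within the scatter, whereas the two steps involving compound 2 were larger. A small addition to a ring that already gives a low number is therefore expected to move it little. Compound 4 is expected to show a step of a 1.2-fold higher number from compound 3 to compound 4 (0.06 log units; within the scatter), within the scatter, and its estimated value in this assay is 60 nM, with a range from 25 nM to 150 nM.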

Compound 4, half-maximal inhibitory concentration: 60 nM
The estimate for compound 4 equals the measured number at the digits printed; the measured number falls inside the stated range.
By their numbers in this assay, from the lowest: compounds 1, 3 and 4 (each within the scatter of the next); then compound 2.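

In this assay, methoxy in place of hydrogen on an aromatic carbon, ortho to a large group, turns phenoxy into 2-methoxyphenoxy and gives a 1.2-fold higher number from compound 3 to compound 4 (0.06 log units; within the scatter), a step that stays within the scatter. Among these compounds, the earlier steps each exchanged the whole group on the saturated ring carbon, so this pair is the first to read a substituent on the aromatic ring itself, and it shows that this carbon can carry methoxy with no change in the number beyond the scatter. No measurement shown here bears on why the number holds at this position.

What the compounds shown leave open is whether this carbon would accept other groups as well, such as a hydroxyl, an amine, a carboxylic acid or a longer alkoxy chain, since methoxy is the only substituent seen there. They also leave open whether methoxy would give a step of similar size on the other carbons of this ring, or on the 4-(trifluoromethyl)phenyl group of compound 1 and the thiophen-3-yl group of compound 2.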